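Series notes: chain extension at the shared core

The compounds below may be only part of what the source reports. "The series", "measured", "known", "first", "only" and "open" are said of these compounds alone.

The set compares three analogues on a shared core. Compound 1 `COc1c(C)cnc(C[S+]([O-])c2nnc(-c3ccccc3)o2)c1C` in a functional assay on HUVEC cells (Homo sapiens) for inhibition, read by ELISA (on this read-out lower numbers stand for stronger inhibition and higher numbers for weaker inhibition), gives 7000 nM. Compound 2 `COc1c(C)cnc(C[S+]([O-])c2nnc(-c3cccc(F)c3)o2)c1C` in this assay gives 15000 nM, and compound 3 `COc1c(C)cnc(C[S+]([O-])c2nnc(C)o2)c1C` gives 10000 nM. Compound 3 thus stands second highest of the three numbers; its nearest neighbour is compound 1, with a 1.4-fold higher number from compound 1 to compound 3 (0.15 log units; within the scatter), and compound 2 shows a 1.5-fold lower number from compound 2 to compound 3 (0.18 log units; within the scatter), both within the scatter. Among the measured compounds shown here, the only step beyond the scatter is a 2.1-fold higher number from compound 1 to compound 2 (0.33 log units; beyond the scatter), which concerns a fluoro group on the phenyl ring and does not touch the part changed here.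

Compound 4 `CCc1nnc([S+]([O-])Cc2ncc(C)c(OC)c2C)o1` differs from compound 3 by methyl in place of hydrogen on a saturated chain carbon bound to an aromatic carbon. For the measured compounds named here, no measured step in this set alters the saturated chain carbon bound to an aromatic carbon, so there is no direct precedent. The closest comparison is that exchanging the whole phenyl group for methyl, a 1.4-fold higher number from compound 1 to compound 3 (0.15 log units; within the scatter), left the number within the scatter, which suggests this position of the core accepts variation without a large shift. For compound 4 the expected step is no change at the digits printed from compound 3 to compound 4 (within the scatter), no change beyond the scatter in either direction. Compound 4 is estimated at 10000 nM in this assay, with a range of 5000 nM to 20000 nM.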

Compound 4, half-maximal inhibitory concentration: 12000 nM
Beside the measured number, compound 4's estimate is 1.2-fold (0.08 log units) below it; the measured number falls inside the stated range.
By their numbers in this assay, from the lowest: compounds 1, 3, 4 and 2 (each within the scatter of the next, the first and the last beyond it).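

In this assay (this assay), the saturated chain carbon bound to an aromatic carbon now has its first direct reading: methyl in place of hydrogen, which turns the methyl of compound 3 into the ethyl of compound 4, gives (a 1.2-fold higher number from compound 3 to compound 4 (0.08 log units; within the scatter)), so the added methyl produces no shift that can be told from the scatter. Among the compounds shown here, the wider exchanges read the same way, with ethyl in place of 3-fluorophenyl giving (a 1.3-fold lower number from compound 2 to compound 4 (0.10 log units; within the scatter)) and ethyl in place of phenyl giving (a 1.7-fold higher number from compound 1 to compound 4 (0.23 log units; within the scatter)), so the ethyl compound cannot be separated from either aryl compound, even though the step between those two aryl compounds is the one step in the set beyond the scatter. No measured information on the series accounts for this insensitivity.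

From the compounds shown here alone, whether a longer chain, such as propyl or butyl, would continue this flat reading or finally move the number beyond the scatter remains open. Also open, going by these compounds, is whether a group of another kind at this place, such as an amine or a carboxylic acid, would shift the number in either direction.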